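This account rests on a few compounds, and the source may have more. Where it says the series, first, only, none or still open, it means among the compounds named here.

Measured compounds: compound 1 `COC(=O)/C=C/c1cccc(N(Cc2ccc(/C=C/C(=O)O)cc2)C(=O)C2CCCCC2)c1`, compound 2 `COC(=O)/C=C/c1cccc(N(Cc2ccc(/C=C/C(=O)OC(C)(C)C)cc2O)C(=O)C2CCCCC2)c1`.

In an assay on isolated protein with Bile acid receptor (Homo sapiens) as the target (on this read-out lower numbers stand for an effect already at smaller amounts and higher numbers for an effect only at larger amounts of compound), compound 1 gives 1000 nM, and compound 2 gives 1000 nM, so compound 1 stands level with compound 2 within the scatter. Compound 3 `COC(=O)/C=C/c1cccc(N(Cc2ccc(/C=C/c3cccc(Cl)c3)cc2)C(=O)C2CCCCC2)c1` is not yet measured. It differs from compound 1 by 3-chlorophenyl in place of carboxy on a double-bonded chain carbon bound to a double-bonded chain carbon. Within the data shown here, no measured step of this kind is at hand. A small loss is expected for compound 3, reading a 2.0-fold higher number from compound 1 to compound 3 (0.30 log units; within the scatter), since the carboxy is removed entirely, though the loss is kept modest because compound 2 gives 1000 nM without a free acid. Compound 3 is therefore estimated at 2000 nM, within 500 nM to 8000 nM.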

Compound 3, half-maximal effective concentration: 166 nM
Compound 3: middle estimate off by 12-fold (1.08 log units), on the high side, and the stated range ends above it.
By their numbers in this assay, from the lowest: compound 3; then compounds 1 and 2 (each within the scatter of the next).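

In this assay, 3-chlorophenyl in place of carboxy on a double-bonded chain carbon bound to a double-bonded chain carbon gives a 6.0-fold lower number from compound 1 to compound 3 (0.78 log units; beyond the scatter), a gain beyond the scatter. The free acid is therefore not needed at this position for a lower number, and an aromatic ring of carbon only is accepted there. No data at hand give a reason for this gain.

Open, going by these compounds, is what the chlorine itself contributes. A plain phenyl or a pyridyl at the same place could show whether the gain stays.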